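The compounds below may be only part of what the source reports. "The series", "measured", "known", "first", "only" and "open" are said of these compounds alone.

Working notes on the series, all run in a functional assay on SW480 cells (Homo sapiens) for antiproliferative activity, read by MTT assay, with a stated time of 48 h; on this read-out higher numbers stand for weaker inhibition and lower numbers for stronger inhibition.

Compound 2 `CC(C)=CCC[C@]1(C)/C=C/[C@@H](OC(=O)C=C(C)C)[C@](C)(O)/C=C/C(=O)/C(CCl)=C\C1` gives 390 nM, the lowest of the three numbers in hand. Compound 1 `CO[C@]1(C)/C=C/C(=O)/C(CO)=C\C[C@](C)(CCC=C(C)C)/C=C/[C@H]1OC(=O)C=C(C)C` gives 15200 nM, the nearer of the other two and still well beyond the scatter from compound 2. Compound 3 `CC(C)=CCC[C@]1(C)/C=C/[C@@H](OC(=O)C=C(C)C)[C@](C)(O)/C=C/C(=O)/C(C[Si](c2ccccc2)(c2ccccc2)C(C)(C)C)=C\C1` gives 20700 nM, the furthest of the three from compound 2, again beyond the scatter. Compound 2 therefore stands as the most potent of the measured set.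

Compound 4 `CC(C)=CCC[C@]1(C)/C=C/[C@@H](OC(=O)C=C(C)C)[C@](C)(O)/C=C/C(=O)/C(COC(=O)c2ccc([N+](=O)[O-])cc2)=C\C1` has no number yet. It departs from compound 2 by a single change: ((4-nitrophenyl)carbonyl)oxy in place of chloro on a saturated chain carbon bound to a double-bonded ring carbon. For the measured compounds named here, no measured pair shows exactly this swap, so its size has to be judged from what the other two values show. Going by the values given here, the one other compound carrying a large group at the same place, compound 3, gives 20700 nM where compound 2 gives 390 nM; the small chloro of compound 2 is the only variant at this place with a strong number. On that basis compound 4 is expected to lose potency, with a step of a 10-fold higher number from compound 2 to compound 4 (1.01 log units; beyond the scatter) that lies beyond the scatter. The estimate for compound 4 is 4000 nM, within a range of 800 nM to 20000 nM.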

Compound 4, half-maximal inhibitory concentration: 570 nM
The estimate for compound 4 lay 7.0-fold (0.85 log units) above the measured number, and the stated range ends above it.
By their numbers in this assay, from the lowest: compounds 2 and 4 (each within the scatter of the next); then compounds 1 and 3 (each within the scatter of the next).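

In this assay, ((4-nitrophenyl)carbonyl)oxy in place of chloro on a saturated chain carbon bound to a double-bonded ring carbon gives a 1.5-fold higher number from compound 2 to compound 4 (0.16 log units; within the scatter), so this place accepts a group of 12 heavy atoms, with a six-membered aromatic ring of carbon only and 4 hydrogen-bond acceptors, with no change beyond the scatter. Chloro is therefore no longer the only variant here with a strong number, and a large group at this place does not by itself go with a weak number; compound 3 goes against any such link, as compound 3 gives 20700 nM with its large silicon-bearing group at the same place. The data on hand give no reason for the gap between the large groups of compound 3 and compound 4.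

Open is which part of the entering group matters, as an acetyl ester, an unsubstituted benzoyl ester and an amine at this place are not among the compounds shown. Compound 1 differs from compound 2 in two places, so the effect of a plain hydroxy at this place cannot be read on its own.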